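The source may hold more compounds than are shown below. What is called first, only, known or untested is meant among the compounds shown, and "the series" means these compounds.

Working notes on the series, read in a functional assay on COLO 205 cells (Homo sapiens) for cytotoxicity, read by MTT assay, with a stated time of 48 h; on this read-out lower numbers stand for stronger inhibition and higher numbers for weaker inhibition. Compound 1 `CCOC(=O)C1=C(C)NC(=S)NC1c1cccc(OCCCCOc2cccc(C3NC(=S)NC(C)=C3C(=O)OCC)c2)c1` gives > 200 ug/mL, which is a limit of the assay and not a number. For the measured compounds named here, compound 2 `CCOC(=O)C1=C(C)NC(=S)NC1c1cccc(OC/C=C\COc2cccc(C3NC(=S)NC(C)=C3C(=O)OCC)c2)c1` gives 64 ug/mL, the only actual number so far, so its standing rests on that single reading. Compound 3 `CCOC(=O)C1=C(C)NC(=S)NC1c1cccc(OC/C=C/COc2cccc(C3NC(=S)NC(C)=C3C(=O)OCC)c2)c1` is the next to be read, and the change is the two compounds have the same atoms and bonds; at least one stereo element is drawn with a configuration in one of them and without one in the other: 1 of 3 stereo elements differ; a double bond is drawn Z in compound 2 and E in compound 3. The double bond is drawn Z in compound 2 and E in compound 3, while the atoms and bonds stay the same. Going by the values given here, no measured pair sizes such a change. With compound 2 at 64 ug/mL as the only anchor, the expected step of a 1.1-fold higher number from compound 2 to compound 3 (0.04 log units; within the scatter) in this assay is none beyond the scatter, with no direction favoured. For compound 3 the estimated value is 70 ug/mL, with an expected range of 25 ug/mL to 190 ug/mL.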

Compound 3, half-maximal inhibitory concentration: > 200 ug/mL
Compound 3: a limit, no number; the forecaster's own chance of this, stated with the estimate: 20%; at least 2.8-fold (0.45 log units) between middle value and limit.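

The change from a Z to an E double bond, with the atoms and bonds unchanged, gives an at least 3.1-fold higher number from compound 2 to compound 3 (0.49 log units; beyond the scatter) in this assay. From the compounds shown here alone, compound 3 gives > 200 ug/mL, a limit of the assay and not a number, so this step has a lower bound only and its full size stays unknown: the limit of > 200 ug/mL in this assay, at which 2 of the 3 values shown sit. In this pair, the reading therefore depends on the double-bond configuration, and the comparison rests on that configuration as drawn: the fact that one of compounds 2 and 3 is drawn with a defined configuration and the other without, at the place where they differ.

The compounds shown leave open whether a Z double bond in a longer chain would also give a reading short of the limit. They also leave open whether a carboxylic acid in place of the ethyl ester would keep the reading of compound 2.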